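This account rests on a few compounds, and the source may have more. Where it says the series, first, only, none or still open, it means among the compounds named here.

For the measured compounds named here, compound 2 `CC(C)c1cccc(C(C)C)c1NC(=O)Nc1nc2ccccc2n1-c1ncccc1Cl` gives 100 nM in an assay on isolated protein for displacement of a labelled ligand from acyl-CoA:cholesterol acyltransferase (Oryctolagus cuniculus) (on this read-out higher numbers stand for weaker inhibition and lower numbers for stronger inhibition), the highest of the two numbers so far; compound 1 `Cc1ccccc1-n1c(NC(=O)Nc2c(C(C)C)cccc2C(C)C)nc2ccccc21` gives 19 nM. Compound 3 `Cc1ncccc1-n1c(NC(=O)Nc2c(C(C)C)cccc2C(C)C)nc2ccccc21` carries 2-methylpyridin-3-yl in place of 3-chloropyridin-2-yl on an aromatic nitrogen. Going by the values given here, the single step bearing on this change is a 5.3-fold higher number from compound 1 to compound 2 (0.72 log units; beyond the scatter), where the 3-chloropyridin-2-yl group set the high end of the series. Compound 3 shares the methyl of the 2-methylphenyl group of compound 1, so a partial return toward the lower number is expected, a 2.5-fold lower number from compound 2 to compound 3 (0.40 log units; beyond the scatter). Compound 3 is accordingly estimated at 40 nM in this assay, within 15 nM to 110 nM.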

Compound 3, half-maximal inhibitory concentration: 100 nM
Beside the measured number, compound 3's estimate is 2.5-fold (0.40 log units) below it, within the range that was stated.
By their numbers in this assay, from the lowest: compound 1; then compounds 2 and 3 (each within the scatter of the next).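

With 2-methylpyridin-3-yl in place of 3-chloropyridin-2-yl, this assay shows no change at the digits printed from compound 2 to compound 3 (within the scatter), so these two groups on the aromatic nitrogen cannot be told apart here. With 2-methylpyridin-3-yl in place of 2-methylphenyl, the same read-out shows a 5.3-fold higher number from compound 1 to compound 3 (0.72 log units; beyond the scatter), so the methyl shared with compound 1 does not by itself keep the lower number. No evidence is available on what lies behind either step.

Still open, on these data alone, is how an amine or a methoxy group in place of that methyl would read in this assay. Also open, as far as these compounds go, is whether a plain phenyl on the aromatic nitrogen would stay with compound 1 or with compound 3.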